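The source may hold more compounds than are shown below. What is called first, only, known or untested is meant among the compounds shown, and "the series" means these compounds.

In a functional assay on DU-145 cells (Homo sapiens) for cytotoxicity, read by trypan blue exclusion, with a stated time of 96 h (a higher number here means a weaker inhibitor, a lower number a stronger inhibitor), compound 2 `COc1ccc(CS(=O)(=O)/C=C/c2c(OC)cccc2OC)cc1[N+](=O)[O-]` gives 20000 nM. Among the measured compounds shown here, compound 1 `COc1ccccc1/C=C/S(=O)(=O)Cc1ccc(OC)c([N+](=O)[O-])c1` gives the same 20000 nM, and these two share the highest number so far, while compound 3 `COc1ccc(CS(=O)(=O)/C=C/c2c(OC)cccc2OC)cc1N` gives 50 nM. Compound 4 `COc1cc(OC)c(/C=C/S(=O)(=O)Cc2ccc(OC)c([N+](=O)[O-])c2)c(OC)c1` retains the nitro group of compound 2 and differs from it by methoxy in place of hydrogen on an aromatic carbon. The same kind of swap has already been measured once, giving no change at the digits printed from compound 1 to compound 2 (within the scatter). For the measured compounds named here, the only large measured change, a 400-fold lower number from compound 2 to compound 3 (2.60 log units; beyond the scatter), came from amino in place of nitro, a swap not made here. The expected step in this assay is therefore no change at the digits printed from compound 2 to compound 4 (within the scatter), with nothing beyond the scatter anticipated. Compound 4 is estimated at 20000 nM, within an expected range of 6000 nM to 50000 nM.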

Compound 4, half-maximal inhibitory concentration: 2500 nM
Estimate against measurement, compound 4: 8.0-fold (0.90 log units) above; measured number outside the range, below it.
By their numbers in this assay, from the lowest: compound 3; then compound 4; then compounds 1 and 2 (each within the scatter of the next).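

In this assay, methoxy in place of hydrogen on an aromatic carbon, here para to a large group and meta to two methoxy groups, gives an 8.0-fold lower number from compound 2 to compound 4 (0.90 log units; beyond the scatter), so this swap can lower the number while the nitro group stays. The same kind of swap gave no change at the digits printed from compound 1 to compound 2 (within the scatter), so its outcome is not the same on every compound. Nothing available here explains this difference. Still open, going by these compounds, is whether ethoxy or a hydroxyl group on this carbon would lower the number further. Also open, on these data alone, is whether the amino-for-nitro swap, which gave a 400-fold lower number from compound 2 to compound 3 (2.60 log units; beyond the scatter), would have a similar effect on compound 4.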